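The compounds below may be only part of what the source reports. "The series", "measured", "known", "first", "only" and "open" are said of these compounds alone.

Measured so far:
compound 1 `C#Cc1c(-c2ccccc2)[nH]c2ccccc12` gives 1610 nM
compound 2 `Cc1ccccc1-c1cc2cc([N+](=O)[O-])ccc2[nH]1` gives 6870 nM
compound 3 `c1cncc(-c2cc3ccccc3[nH]2)c1` gives 3050 nM

In an assay on isolated protein for inhibition of Aromatase (Homo sapiens), read by fluorescence, using NADPH, with a stated time of 30 min (on this read-out lower numbers stand for stronger inhibition and higher numbers for weaker inhibition), the three measured compounds span a narrow band. Compound 3 stands second highest of the three numbers. Its nearest neighbour is compound 1, whose number is lower, though the two lie within the usual scatter of each other, so no order between them can be claimed. Compound 2 lies furthest away, with a number higher than that of compound 3 by a margin beyond the scatter.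

The next compound in this account, compound 4 `N#Cc1ccc2[nH]c(-c3cccnc3)cc2c1`, is compound 3 with one change: cyano in place of hydrogen on an aromatic carbon.

Within the data shown here, no pair among the measured compounds differs by this change alone, so nothing in the data fixes the size of the step. The account therefore rests on expectation. Compound 4 is expected to give a number somewhat lower than that of compound 3 in this assay, with a step of a 2.0-fold lower number from compound 3 to compound 4 (0.31 log units; beyond the scatter), close to the edge of the scatter. The estimate for compound 4 is 1500 nM, within a range from 400 nM to 6000 nM.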

Compound 4, half-maximal inhibitory concentration: 11500 nM
Estimate against measurement, compound 4: 7.7-fold (0.88 log units) below, and the stated range ends below it.
By their numbers in this assay, from the lowest: compounds 1 and 3 (each within the scatter of the next); then compounds 2 and 4 (each within the scatter of the next).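

In this assay cyano in place of hydrogen on this aromatic carbon gives a 3.8-fold higher number from compound 3 to compound 4 (0.58 log units; beyond the scatter), a modest step and the first in this account to isolate a single place. It shows that this carbon of the six-membered aromatic ring is not indifferent to substitution: here the nitrile weakens inhibition rather than strengthening it. Nothing among the data shown accounts for the direction of this step.

As far as these compounds go, whether the loss belongs to cyano itself or would follow any group placed on this carbon stays open, and fluorine, a methoxy group or an amine at the same place would separate those readings. Also open, from the compounds shown here alone, is whether the same change would carry a similar step on the core of compound 1.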